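Swapping the naphthalene arm on the triazole ring

This account rests on a few compounds, and the source may have more. Where it says the series, first, only, none or still open, it means among the compounds named here.

Three compounds share a long chain built around two secondary alcohols, an ether linker and a biphenyl end, with a triazole ring that carries a varying group on one of its nitrogens. In a functional assay on SGC-7901 cells (Homo sapiens) for inhibition, read by MTT assay, with a stated time of 72 h (on this read-out higher numbers stand for weaker inhibition of growth and lower numbers for stronger inhibition of growth), compound 1 `CC1=C(C)C(=O)C(CCCCCCCCCCn2cc(C[C@H](O)COCCOC[C@@H](O)Cc3ccc(-c4ccccc4)cc3)nn2)=C(C)C1=O` gives 350 nM and compound 3 `CC1=C(CCCCCCCCCCn2cc(C[C@H](O)COCCOC[C@@H](O)Cc3ccc(-c4ccccc4)cc3)nn2)C(=O)c2ccccc2C1=O` gives 390 nM. Compound 2 `O[C@H](COCCOC[C@@H](O)Cc1cn(Cc2ccc3ccccc3c2)nn1)Cc1ccc(-c2ccccc2)cc1` gives 12100 nM in this assay, the highest of the three numbers, and both of its gaps to compounds 1 and 3 lie beyond the scatter, so on these numbers compound 2 is the weakest inhibitor of growth.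

Compound 4 `O=C1COc2ccc(-n3cc(C[C@H](O)COCCOC[C@@H](O)Cc4ccc(-c5ccccc5)cc4)nn3)cc2N1` has not yet been measured. It differs from compound 2 by a group of 11 heavy atoms (8 carbon, 1 nitrogen, 2 oxygen; one six-membered non-aromatic ring with 2 hetero atoms, one six-membered aromatic ring of carbon only) in place of a group of 11 heavy atoms (11 carbon; 2 six-membered aromatic rings of carbon only), on an aromatic nitrogen; in words, a group of 11 heavy atoms (8 carbon, 1 nitrogen, 2 oxygen; one six-membered non-aromatic ring with 2 hetero atoms, one six-membered aromatic ring of carbon only) replaces a group of 11 heavy atoms (11 carbon; 2 six-membered aromatic rings of carbon only), on an aromatic nitrogen. Among the measured compounds shown here, no measured pair shows this kind of change, so the expected step from compound 2 to compound 4 in this assay is a 1.2-fold lower number from compound 2 to compound 4 (0.08 log units; within the scatter), not beyond the scatter in either direction. Compound 4 is therefore estimated at 10000 nM, within a range from 3000 nM to 40000 nM.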

Compound 4, concentration for 50% growth inhibition: 15200 nM
Compound 4: middle estimate off by 1.5-fold (0.18 log units), on the low side, and the stated range covers the measured number.
By their numbers in this assay, from the lowest: compounds 1 and 3 (each within the scatter of the next); then compounds 2 and 4 (each within the scatter of the next).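

On the aromatic nitrogen of the five-membered aromatic ring, the (naphthalen-2-yl)methyl group of compound 2 gives way to a group of the same heavy-atom count that brings in nitrogen, oxygen, a non-aromatic ring, 1 hydrogen-bond donor and 2 hydrogen-bond acceptors. In this assay, this gives a 1.3-fold higher number from compound 2 to compound 4 (0.10 log units; within the scatter), so the two compounds cannot be told apart, even though the new group differs so much in its atoms. Nothing available explains this result.

Among the compounds shown here, this single pair cannot show how far that tolerance extends, since it covers only two groups at this nitrogen. Going by these compounds, whether a smaller group such as methyl, or a group carrying an amine or a carboxylic acid, would also stay within the scatter of compound 2 remains open.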